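The source may hold more compounds than are shown below. What is called first, only, known or untested is meant among the compounds shown, and "the series" means these compounds.

Three compounds share one core and differ only in the group on the sulfonyl sulfur: compound 1 `O=C(NS(=O)(=O)c1ccc(F)cc1)c1ccc(Nc2nc(NC3(c4ccc(Cl)cc4)CC3)nc(OCC(F)(F)F)n2)cc1`, compound 2 `CC(C)S(=O)(=O)NC(=O)c1ccc(Nc2nc(NC3(c4ccc(Cl)cc4)CC3)nc(OCC(F)(F)F)n2)cc1` and compound 3 `CC(C)(C)NC(=O)NCCS(=O)(=O)NC(=O)c1ccc(Nc2nc(NC3(c4ccc(Cl)cc4)CC3)nc(OCC(F)(F)F)n2)cc1`. In a physicochemical assay for permeability, using PAMPA, at pH 7.4 (a higher number here means that the compound crosses the layer faster, a lower number that the compound crosses the layer more slowly), compound 1 gives 193 nm/s, compound 2 gives 31 nm/s and compound 3 gives 49 nm/s, which places compound 3 second of the three measured numbers. The measured steps are a 6.2-fold lower number from compound 1 to compound 2 (0.79 log units; beyond the scatter), a 3.9-fold lower number from compound 1 to compound 3 (0.60 log units; beyond the scatter) and a 1.6-fold higher number from compound 2 to compound 3 (0.20 log units; within the scatter). Compound 4 `CC(C)(C)OC(=O)NCCS(=O)(=O)NC(=O)c1ccc(Nc2nc(NC3(c4ccc(Cl)cc4)CC3)nc(OCC(F)(F)F)n2)cc1` keeps the chain of compound 3 and changes only its far end: tert-butoxy in place of (tert-butyl)amino on a carbonyl carbon. For the measured compounds named here, none of the measured steps alters this part of the molecule; all three concern the sulfonyl substituent, and the only step that keeps a chain of this kind stayed within the scatter. The expected step is therefore a 1.2-fold higher number from compound 3 to compound 4 (0.09 log units; within the scatter), not beyond the scatter. Compound 4 is estimated at 60 nm/s, with a range from 30 nm/s to 120 nm/s.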

Compound 4, apparent permeability: 111 nm/s
Estimate against measurement, compound 4: 1.9-fold (0.27 log units) below; the measured number falls inside the stated range.
By their numbers in this assay, from the lowest: compounds 2 and 3 (each within the scatter of the next); then compounds 4 and 1 (each within the scatter of the next).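

In this assay the far end of the chain counts as well as the sulfonyl substituent: tert-butoxy in place of (tert-butyl)amino on a carbonyl carbon gives (a 2.3-fold higher number from compound 3 to compound 4 (0.36 log units; beyond the scatter)), beyond the scatter. With this end, the chain stands clear of isopropyl (a 3.6-fold higher number from compound 2 to compound 4 (0.55 log units; beyond the scatter)), while its step from 4-fluorophenyl (a 1.7-fold lower number from compound 1 to compound 4 (0.24 log units; within the scatter)) lies within the scatter. The change removes one hydrogen-bond donor and adds one hydrogen-bond acceptor, but nothing available links the step to either count. Open, on these data alone, is how a free amine or a carboxylic acid at this chain end would read, and whether a longer chain carrying the tert-butoxycarbonyl group keeps the step.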